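Swapping Cyclopentyl for Pyrrolidin-1-yl on a Sulfonyl Sulfur

The compounds below may be only part of what the source reports. "The series", "measured", "known", "first", "only" and "open" are said of these compounds alone.

In an ADME assay on the whole organism for pharmacokinetics, with Rattus norvegicus as the target (on this read-out lower numbers stand for lower oral bioavailability and higher numbers for higher oral bioavailability), compound 1 `O=S(=O)(c1cc(F)c(O)c2ncccc12)C1CCCC1` gives 32% and compound 2 `O=S(=O)(c1cc(Cl)c(O)c2ncccc12)C1CCCC1` gives 37%. These two numbers lie within the usual scatter of each other, so compound 2 cannot be separated from compound 1. The next structure, compound 3 `O=S(=O)(c1cc(Cl)c(O)c2ncccc12)N1CCCC1`, keeps the rest of compound 2 but has pyrrolidin-1-yl in place of cyclopentyl on a sulfonyl sulfur. Among the measured compounds shown here, only one measured step is available, a number 5 percentage points higher from compound 1 to compound 2 (within the scatter). For the measured compounds named here, it concerns a different change, on an aromatic carbon, so it offers only weak guidance here, and no measured step shows what this swap does. No change beyond the scatter in this assay is therefore expected, and the estimated step is a number 2 percentage points lower from compound 2 to compound 3 (within the scatter). For compound 3 the expected value is 35%, with an estimated range from 15% to 55%.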

Compound 3, oral bioavailability: 33%
Compound 3: the middle estimate sits 2 percentage points above what was measured, and the stated range covers the measured number.
By their numbers in this assay, from the lowest: compounds 1, 3 and 2 (each within the scatter of the next).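

Among the compounds shown here, this is the first measured step at the sulfonyl sulfur, since the earlier pair differed only on an aromatic carbon. In this assay, pyrrolidin-1-yl in place of cyclopentyl gives a number 4 percentage points lower from compound 2 to compound 3 (within the scatter), so exchanging one ring carbon for a nitrogen in a ring of the same size produces no change that can be told apart from repeat-measurement noise. Nothing measured here bears on the reason for this result.

Still open, on these data alone, is whether a different group on the sulfonyl sulfur, such as a morpholine ring, a dimethylamino group or a longer carbon chain, would shift oral bioavailability beyond the scatter. As far as these compounds go, it is also open whether pyrrolidin-1-yl would behave the same way with fluoro in place of chloro on the aromatic carbon.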